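This account rests on a few compounds, and the source may have more. Where it says the series, first, only, none or still open, it means among the compounds named here.

Compound 1 `CS(=O)(=O)c1ccc(-c2cc(C(O)(C(F)(F)F)C(F)(F)F)cnc2N2CCN(S(=O)(=O)c3ccc(N)nc3)CC2)cc1`: 32 mL.min-1.g-1
Compound 2 `Nc1ccc(S(=O)(=O)N2CCN(c3ncc(C(O)(C(F)(F)F)C(F)(F)F)cc3-c3cncc(F)c3)CC2)cn1`: 24 mL.min-1.g-1

In an ADME assay (liver) for metabolic stability, with Liver microsome (Homo sapiens) as the target, using microsomes and NADPH, with a stated time of 30 min, tested at 1 uM (a higher number here means faster removal of the compound, a lower number slower removal), compound 2 gives 24 mL.min-1.g-1. This value cannot be ranked against that of compound 1. The two values lie within the scatter of each other. Compound 3 `COc1ccc(-c2cc(C(O)(C(F)(F)F)C(F)(F)F)cnc2N2CCN(S(=O)(=O)c3ccc(N)nc3)CC2)cn1` carries 6-methoxypyridin-3-yl in place of 5-fluoropyridin-3-yl on an aromatic carbon. Within the data shown here, the only measured swap at this place gave a 1.3-fold lower number from compound 1 to compound 2 (0.12 log units; within the scatter). One small step is thin evidence, but it gives no reason to expect a shift beyond the scatter in this assay. The expected step is a 1.2-fold higher number from compound 2 to compound 3 (0.07 log units; within the scatter). For compound 3 the estimate is 28 mL.min-1.g-1, with an expected range of 14 mL.min-1.g-1 to 56 mL.min-1.g-1.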

Compound 3, intrinsic clearance in microsomes: 25 mL.min-1.g-1
Compound 3: middle estimate off by 1.1-fold (0.05 log units), on the high side; measured number inside the range.
By their numbers in this assay, from the lowest: compounds 2, 3 and 1 (each within the scatter of the next).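

In this assay, the step from 5-fluoropyridin-3-yl to 6-methoxypyridin-3-yl gives a 1.0-fold higher number from compound 2 to compound 3 (0.02 log units; within the scatter), and the step from 4-(methylsulfonyl)phenyl to the same group gives a 1.3-fold lower number from compound 1 to compound 3 (0.11 log units; within the scatter). All three ring groups at this place on the shared core therefore lie within the scatter of one another, so a second pyridine and a third substituent have not moved the number beyond it. Nothing given here explains these numbers.

As far as these compounds go, it remains open whether a group of another kind at this place, such as a carboxylic acid, an amine or a saturated piperidine ring, would shift the number beyond the scatter.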